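Swapping nitro for methyl on a weaker core

This account rests on a few compounds, and the source may have more. Where it says the series, first, only, none or still open, it means among the compounds named here.

Measured compounds:
Compound 1 `COC(=O)C1(c2ccc(C)cc2)CC1CN1CCC(Cc2ccccc2)CC1`: 0.97 nM
Compound 2 `COC(=O)C1(c2ccc([N+](=O)[O-])cc2)CC1CN1CCC(Cc2ccccc2)CC1`: 0.68 nM
Compound 3 `COC(=O)C1(c2ccc([N+](=O)[O-])cc2)CC1CN1CCN(c2ncccn2)CC1`: 619 nM

Compounds 1 and 2 share one core and differ only at the aromatic ring: methyl in place of nitro on an aromatic carbon. In an assay for displacement of a labelled ligand from Sigma non-opioid intracellular receptor 1 (Cavia porcellus) (a lower number here means a stronger inhibitor, a higher number a weaker inhibitor), this gave a 1.4-fold higher number from compound 2 to compound 1 (0.15 log units; within the scatter), so the two values sit together. Compound 3 carries the same nitro group on a different core, and in this assay compound 3 gives 619 nM, a far higher number than compound 1 or compound 2. The difference between the two cores is not broken down here.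

Compound 4 `COC(=O)C1(c2ccc(C)cc2)CC1CN1CCN(c2ncccn2)CC1` has not been measured. It differs from compound 3 by methyl in place of nitro on an aromatic carbon, the same change seen between compound 2 and compound 1, at the same place. Because that earlier step was a 1.4-fold higher number from compound 2 to compound 1 (0.15 log units; within the scatter), a step of similar size is expected here, estimated as a 1.3-fold higher number from compound 3 to compound 4 (0.11 log units; within the scatter). Compound 4 is therefore expected to give about 800 nM, likely between 250 nM and 2500 nM, resting on the core-dependent gap from compound 1 to compound 3 rather than on the substituent swap.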

Compound 4, inhibition constant: 353 nM
The estimate for compound 4 lay 2.3-fold (0.36 log units) above the measured number, within the range that was stated.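

In this assay, putting methyl in place of nitro gives a 1.8-fold lower number from compound 3 to compound 4 (0.24 log units; within the scatter), so on this second core the swap again leaves the number within the usual scatter. Set side by side, the steps on the two cores cannot be told apart: the same change on two cores in this assay, a 1.4-fold higher number (0.15 log units; within the scatter) from compound 2 to compound 1 and a 1.8-fold lower number (0.24 log units; within the scatter) from compound 3 to compound 4, 2.5-fold (0.40 log units) apart, within the scatter of two such steps

This shows that, for these two pairs, the swap carried over from one core to the other without a measurable effect on either, even though the cores give very different numbers. It does not show that the swap would behave the same way on a further core, and a small real effect of either group could still be hidden within the scatter.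

At this place on the aromatic ring, para to a large group, the compounds shown carry only nitro and methyl, so it remains open whether an amine or a carboxylic acid there would also leave the number unchanged. Also open is which part of the two cores accounts for the large gap between them.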